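Swapping a thiazole for a cyclobutane on the ether oxygen

The compounds below may be only part of what the source reports. "The series", "measured", "known", "first", "only" and "open" are said of these compounds alone.

Of the compounds shown here, three from one series have been measured in an ADME assay on the whole organism (Rattus norvegicus) for pharmacokinetics, using cassette dosing, at a dose of 1 mg/kg by the oral route; on this read-out higher numbers stand for higher oral bioavailability and lower numbers for lower oral bioavailability. Compound 1 `C[C@@H](Cn1c(=O)[nH]/c(=N\c2ccc(Oc3nccs3)cc2)n(Cc2ccc(Cl)cc2)c1=O)C(=O)O` gives 41.4% in this assay, the lowest of the three numbers. Compound 2 `CC(C)Oc1ccc(Nc2nc(=O)n(CCO)c(=O)n2Cc2ccc(Cl)cc2)cc1Cl` gives 48.1%, which lies within the usual scatter of the number for compound 1. Compound 3 `CC(C)Oc1ccc(/N=c2\[nH]c(=O)n(CC(C)(C)C(=O)O)c(=O)n2Cc2ccc(Cl)cc2)cc1Cl` gives 85.3%, well beyond the scatter above compound 1. No two of these three differ in only one place, so the gaps between them cannot be tied to a single change.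

Compound 4 `C[C@@H](Cn1c(=O)[nH]/c(=N\c2ccc(OC3CCC3)cc2)n(Cc2ccc(Cl)cc2)c1=O)C(=O)O` has not yet been measured. It differs from compound 1 by cyclobutyl in place of 1,3-thiazol-2-yl on an oxygen on an aromatic ring; read one bond further out, the change is from (1,3-thiazol-2-yl)oxy to cyclobutyloxy. Among the measured compounds shown here, with no measured single step of this kind to lean on, the expectation for the step from compound 1 to compound 4 in this assay is a modest rise, a number 13.6 percentage points higher from compound 1 to compound 4 (beyond the scatter), at about the edge of the scatter. Compound 4 is therefore estimated at 55%, within a range of 32% to 80%.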

Compound 4, oral bioavailability: 54.3%
Compound 4: middle estimate off by 0.7 percentage points, on the high side; low and high end bracket the measured number.
By their numbers in this assay, from the lowest: compounds 1, 2 and 4 (each within the scatter of the next, the first and the last beyond it); then compound 3.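

Among the compounds shown here, this is the first single change that can be read on its own: in this assay, cyclobutyl in place of 1,3-thiazol-2-yl on an oxygen on an aromatic ring gives a number 12.9 percentage points higher from compound 1 to compound 4 (beyond the scatter) as a modest step. Oral bioavailability at this position therefore does not depend on keeping the aromatic ring with its nitrogen and sulfur, since the ring of carbon only gives a higher number. No measurement shown accounts for this rise, so its reason stays unknown.

This one pair cannot tell whether the same swap would give a similar step on another side-chain or ring substitution pattern. It also leaves open how other groups on this oxygen would read, such as phenyl, cyclopentyl or a longer open chain like butyl.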